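This account rests on a few compounds, and the source may have more. Where it says the series, first, only, none or still open, it means among the compounds named here.

Of the compounds shown here, two of a shared core have been measured in a functional assay on Jurkat cells for inhibition of nuclear factor NF-kappa-B complex (Homo sapiens); a lower number here means a stronger inhibitor, a higher number a weaker inhibitor. Compound 1, `CCOC(=O)c1cnc(-c2ccc(F)cc2)nc1NN1C(=O)C=C(C)C1=O`, gives 700 nM in this assay. Compound 2, `CCOC(=O)c1cnc(-c2cccs2)nc1N(C)N1C(=O)C=C(C)C1=O`, gives 1000 nM in this assay. On these two numbers compound 2 stands highest, but its nearest neighbour is compound 1, whose number lies within the usual scatter of compound 2, so the two cannot be told apart with any confidence.

The next compound, compound 3, `CCOC(=O)c1cnc(-c2ccc(F)cc2)nc1N(C)N1C(=O)C=C(C)C1=O`, has not yet been measured in this assay. It differs from compound 2 in one place: 4-fluorophenyl in place of thiophen-2-yl on an aromatic carbon. Among the measured compounds shown here, compound 3 thereby carries the same 4-fluorophenyl group as compound 1, while differing from compound 1 elsewhere in the molecule, so no measured pair shows this exact change on its own.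

With compound 1 at 700 nM and compound 2 at 1000 nM lying within the scatter of each other, a step of no more than the scatter is expected from compound 2 to compound 3, and the estimate for that step in this assay is a 1.4-fold lower number from compound 2 to compound 3 (0.15 log units; within the scatter). For compound 3 itself the expected value in this assay is 700 nM, with a likely range from 300 nM to 1700 nM.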

Compound 3, half-maximal inhibitory concentration: 3000 nM
Compound 3: middle estimate off by 4.3-fold (0.63 log units), on the low side; measured number outside the range, above it.
By their numbers in this assay, from the lowest: compounds 1 and 2 (each within the scatter of the next); then compound 3.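

In this assay, the group on the aromatic carbon between two ring nitrogen atoms proves to matter: with the methyl on the nitrogen kept, 4-fluorophenyl in place of thiophen-2-yl gives a 3.0-fold higher number from compound 2 to compound 3 (0.48 log units; beyond the scatter), a change that compound 1 and compound 2 could not show on their own, as they differ in two places. With 4-fluorophenyl kept, methyl in place of hydrogen on the nitrogen gives a 4.3-fold higher number from compound 1 to compound 3 (0.63 log units; beyond the scatter), so this small addition also moves the number beyond the scatter, and the closeness of compound 1 and compound 2 was no sign that either change is without effect. No measurement shown here explains why either change gives a weaker inhibitor.

Among the compounds shown here, the thiophen-2-yl group has been seen only with the methyl on the nitrogen, so whether it would also compare well with 4-fluorophenyl when that nitrogen carries hydrogen remains open. Also open, from the compounds shown here alone, is how other groups would behave in these two places, such as a plain phenyl or an amine on the aromatic carbon, or an ethyl or longer chain on the nitrogen.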